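The compounds below may be only part of what the source reports. "The series", "measured", "known", "first", "only" and "open" are said of these compounds alone.

In a physicochemical assay for lipophilicity, read by HPLC, at pH 7.4 (on this read-out lower numbers stand for lower lipophilicity and higher numbers for higher lipophilicity), compound 2 `C[C@@H](Oc1cc2oc(=O)n(CCC(=O)O)c2cc1Cl)c1ccc(Cl)cn1` gives 2.65, the higher of the two numbers in hand, while compound 1 `C[C@@H](Oc1cc2c(cc1Cl)N(CCC(=O)O)C(=O)CO2)c1ccccn1` gives 1.56, a value beyond the scatter below it. Compound 3 `C[C@@H](Oc1cc2oc(=O)n(CCC(=O)O)c2cc1Cl)c1ncccn1` has not yet been measured. It differs from compound 2 in one place: pyrimidin-2-yl in place of 5-chloropyridin-2-yl on a saturated chain carbon bound to an oxygen on an aromatic ring and a saturated chain carbon. For the measured compounds named here, no measured pair shows a change of this kind, so the expectation rests on the structures alone: a fall in this assay well beyond the scatter, estimated as a number 1.45 log units lower from compound 2 to compound 3 (beyond the scatter). Compound 3 is therefore expected to give about 1.2 in this assay, within a range from 0.7 to 1.7.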

Compound 3, distribution coefficient: 0.83
For compound 3 the middle estimate is 0.37 log units above the measured one; low and high end bracket the measured number.
By their numbers in this assay, from the lowest: compound 3; then compound 1; then compound 2.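

In this assay, for the compounds shown here, the step of a number 1.82 log units lower from compound 2 to compound 3 (beyond the scatter) is the first read between compounds that differ in one place. It shows that the group on this saturated chain carbon can by itself move the read-out by a large amount, with the rest of the structure held constant. No measurement bears on the cause of this step.

The change removes a chlorine and adds a ring nitrogen together, leaving the share of each open. Going by these compounds, how a phenyl or a 5-methylpyridin-2-yl group at this place would read also remains open.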